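Swapping an ester for an amide in a lipophilic chain

The source may hold more compounds than are shown below. What is called first, only, known or untested is meant among the compounds shown, and "the series" means these compounds.

Compound 1, `CCCOC(=O)/C=C(C)/C=C/CC(C)CCCC(C)C`, is a long branched chain that ends in a propoxycarbonyl group. Among the measured compounds shown here, in a physicochemical assay for lipophilicity (a lower number here means a more polar compound, a higher number a more lipophilic compound), compound 1 gives 7.28, the highest of the three numbers known here. The nearest of the other two is compound 2, `CCOC(=O)/C=C(C)/C=C/CC(C)CCCC(C)(C)O`, which in this assay gives 4.65, a gap well beyond the scatter. Furthest away is compound 3, `CCOC(=O)/C=C(C)/C=C/CC(C)CCC(OC)C(C)(C)OC`, which in this assay gives 4.34, again beyond the scatter. Compounds 2 and 3 each differ from compound 1 in more than one place, so no single substitution among the measured compounds can be read off as a step of its own.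

Compound 4, `CC(/C=C/CC(C)CCCC(C)C)=C\C(=O)NC(C)C`, differs from compound 1 in just one place: isopropylamino in place of propoxy on a carbonyl carbon. Since no comparable single change has been measured here, the size of the effect has to be estimated rather than read from a neighbouring pair. The expected step is a number 1.28 log units lower from compound 1 to compound 4 (beyond the scatter), downward and beyond the usual scatter. Compound 4 is therefore estimated to give 6 in this assay, with a range from 5.3 to 6.7, while the measurement itself remains to be made.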

Compound 4, partition coefficient: 5.65
The estimate for compound 4 lay 0.35 log units above the measured number; the measured number falls inside the stated range.
By their numbers in this assay, from the lowest: compound 3; then compound 2; then compound 4; then compound 1.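

Swapping propoxy for isopropylamino on a carbonyl carbon gives the first single-place step in this set, and in this assay it is large: a number 1.63 log units lower from compound 1 to compound 4 (beyond the scatter). The two groups match in some of what can be counted, with 4 heavy atoms each, no ring and no net charge, so the step comes with a change in other features: oxygen gives way to nitrogen, and 0 hydrogen-bond donors and 1 hydrogen-bond acceptor give way to 1 hydrogen-bond donor and 0 hydrogen-bond acceptors. No measurement shown here ties the step to any one of these differences.

From the compounds shown here alone, the swap changes both the linking atom and the shape of the carbon chain at once, so the share of each stays open; a straight propylamino group would separate the two, and a dimethylamino group, which has no amide hydrogen, would test the role of that hydrogen. Going by these compounds, whether a step of similar size appears on another chain, such as the hydroxyl-bearing chain of compound 2, also remains unknown.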